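This account rests on a few compounds, and the source may have more. Where it says the series, first, only, none or still open, it means among the compounds named here.

Compound 1 `CCCC[C@H](NC(=O)[C@H](CCCCN)NC(=O)[C@H](CCCNC(=N)N)NC(=O)c1ccc(/C=C2\NC(=S)N(c3ccccc3)C2=O)cc1)C(N)=O`, in an ADME assay for permeability, using PAMPA; a higher number here means that the compound crosses the layer faster, a lower number that the compound crosses the layer more slowly: "impermeable" (no number reported).
Compound 2 `CCCC[C@H](NC(=O)[C@H](CCCCN)NC(=O)[C@H](CCCNC(=N)N)NC(=O)c1ccccc1)C(N)=O`, in this assay: "impermeable" (no number reported).
Compound 3 `CCCC[C@H](NC(=O)[C@H](CCCCN)NC(=O)[C@H](CCCNC(=N)N)NC(=O)c1ccc(/C=C2\SC(=S)N(C3CCCC3)C2=O)cc1)C(N)=O`, in this assay: 2.31 10^-6 cm/s.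

For the measured compounds named here, compound 3 holds the only number among the three: compounds 1 and 2 are recorded without one. Going by the values given here, no pair of measured compounds differs in a single place, so no step is known here. Compound 4 `CCCC[C@H](NC(=O)[C@H](CCCCN)NC(=O)[C@H](CCCNC(=N)N)NC(=O)c1ccc(/C=C2\SC(=S)N(Cc3ccc(OC)cc3)C2=O)cc1)C(N)=O` differs from compound 3 by 4-methoxybenzyl in place of cyclopentyl on an amide-type nitrogen in a ring. Among the compounds with values here, with no comparable step in the data, the change is expected to move the read-out in this assay by no more than the usual scatter, in either direction. Compound 4 is therefore estimated at 2 10^-6 cm/s, within 0.7 10^-6 cm/s to 5.5 10^-6 cm/s, an expected step of a 1.2-fold lower number from compound 3 to compound 4 (0.06 log units; within the scatter).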

Compound 4, apparent permeability: 0.6 10^-6 cm/s
The estimate for compound 4 lay 3.3-fold (0.52 log units) above the measured number, outside the stated range (below it).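

In this assay, 4-methoxybenzyl in place of cyclopentyl on the amide-type nitrogen in the ring gives a 3.9-fold lower number from compound 3 to compound 4 (0.59 log units; beyond the scatter). For the compounds shown here, this is the first step known at this position, and it shows that the read-out depends on which group sits on this nitrogen. Nothing shown gives a reason for the step.

The compounds shown cannot separate the methoxy group from the benzyl part of the entering group. As far as these compounds go, what a plain benzyl, a longer alkyl chain or a chain ending in an amine would give on this nitrogen remains open.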